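The compounds below may be only part of what the source reports. "The series", "measured", "known", "first", "only" and "open" are said of these compounds alone.

Measured so far:
- compound 1, `Cc1cc(C(=O)O)ccc1CN1CCC[C@H](O[C@H](CO)c2cc(F)cc(F)c2)[C@@H]1c1ccccc1`: in an assay on isolated protein for activation of cGMP-dependent protein kinase 1 (Homo sapiens), read by ADP-Glo, with stated times of 30 min and 2 h, in the presence of a further agent that is not named here (a higher number here means that more compound is needed for the effect, a lower number that less compound is needed), compound 1 gives 1500 nM
- compound 2, `Cc1cc(C(=O)O)ccc1CN1CCC[C@H](O[C@H](CO)c2cc(Cl)cc(Cl)c2)[C@@H]1C1CCCCC1`: in this assay compound 2 gives 65000 nM

Only these two numbers exist, and compound 1 stands at the lower of them, so less of compound 1 than of compound 2 is needed. Compound 2 differs from compound 1 in two places at once, so nothing can be said about which of the two changes carries that difference; the two values simply show that compound 1 is the more potent of the pair, by a margin well beyond the usual scatter.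

Compound 3, `Cc1cc(C(=O)O)ccc1CN1CCC[C@H](O[C@H](CO)c2ccnc(Cl)c2)[C@@H]1c1ccccc1`, keeps everything of compound 1 except the aromatic group on the side chain. The change is 2-chloropyridin-4-yl in place of 3,5-difluorophenyl on a saturated chain carbon bound to an oxygen on a saturated carbon and a saturated chain carbon. For the measured compounds named here, no measured step of this kind is available here, so the expectation rests on the change itself: one six-membered aromatic ring is exchanged for another of similar size, while the rest of compound 1 is left untouched. A step of modest size, in either direction, or none beyond the scatter, is the expectation; a 2.0-fold higher number from compound 1 to compound 3 (0.30 log units; within the scatter) is the estimated step. Compound 3 is expected to give about 3000 nM in this assay, with a likely range from 800 nM to 12000 nM.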

Compound 3, half-maximal effective concentration: 50000 nM
Beside the measured number, compound 3's estimate is 17-fold (1.22 log units) below it; the whole stated range lies below it.
By their numbers in this assay, from the lowest: compound 1; then compounds 3 and 2 (each within the scatter of the next).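

Replacing 3,5-difluorophenyl with 2-chloropyridin-4-yl on the saturated chain carbon gives a 33-fold higher number from compound 1 to compound 3 (1.52 log units; beyond the scatter) in this assay. For the compounds shown here, this is the first step here that can be read on its own, as only this one group differs and the rest of the core of compound 1 stays the same. It shows that this position is far from indifferent to which group it carries, even though both groups are six-membered aromatic rings and neither carries a net charge. The swap changes the ring atoms, the halogen and the number of halogens all at once, and no measurement here explains the loss.

The compounds shown cannot say which part of the swap matters, and a ring such as 3-chlorophenyl, which has chlorine but no ring nitrogen, or 2-fluoropyridin-4-yl, which has the ring nitrogen but fluorine in place of chlorine, could begin to separate those parts. Compound 2 still cannot be read as a step from either of the other compounds, since it differs from each in more than one place.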